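The compounds below may be only part of what the source reports. "The series", "measured", "known", "first", "only" and "open" are said of these compounds alone.

Measured compounds:
- compound 1, `O=C(Nc1cc(C(F)(F)F)ccc1Nc1ccc(Br)cc1)c1ccncc1`: 51900 nM
- compound 2, `O=C(Nc1cc(C(F)(F)F)ccc1Nc1ccc(Br)cc1)c1ccccc1`: 6000 nM
- compound 3, `O=C(Nc1cc(C(F)(F)F)ccc1NC1CCCCC1)c1cccnc1`: 52300 nM

In a functional assay on NALM-6 cells (Homo sapiens) for cytotoxicity, read by MTT assay, with a stated time of 48 h (on this read-out higher numbers stand for weaker inhibition and lower numbers for stronger inhibition), compound 2 gives the lowest number of the three; compound 1 and compound 3 both stand well above it, and both gaps lie beyond the scatter. Compound 4, `O=C(Nc1cc(C(F)(F)F)ccc1N1CCCC1)c1ccccc1`, has not yet been measured in this assay. It differs from compound 2 in one place: pyrrolidin-1-yl in place of (4-bromophenyl)amino on an aromatic carbon.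

Among the measured compounds shown here, only one step between measured compounds changes a single group, an 8.7-fold lower number from compound 1 to compound 2 (0.94 log units; beyond the scatter), and that change sits on the carbonyl carbon, not on the aromatic carbon touched here. Compound 1 and compound 3 give nearly the same numbers, but they differ from each other in two places, so they show nothing clean about the amino group alone. For the measured compounds named here, no measured step therefore bears directly on the change from compound 2 to compound 4, and the expectation rests on little.

With no guide in the data, the step of a 2.5-fold higher number from compound 2 to compound 4 (0.40 log units; beyond the scatter) is taken as an expected modest rise in the number, with a wide band around it. Compound 4 is estimated at 15000 nM, expected somewhere between 4000 nM and 60000 nM.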

Compound 4, half-maximal inhibitory concentration: "not active" (no number reported)
Compound 4: no number reported; there is nothing to compare the estimate with.
By their numbers in this assay, from the lowest: compound 2; then compounds 1 and 3 (each within the scatter of the next).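

In this assay compound 4 is reported as "not active" with no number, so its step from compound 2 cannot be sized. No evidence here bears on this result. The compounds shown leave open how much of the gap comes from pyrrolidin-1-yl replacing (4-bromophenyl)amino, and how other groups at that aromatic carbon would behave.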